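Swapping the phenyl end for an acetyl-hydroxyphenyl end

The source may hold more compounds than are shown below. What is called first, only, known or untested is meant among the compounds shown, and "the series" means these compounds.

Measured compounds:
compound 1, `O=C(O)c1cc(=O)c2ccc(OCCCCCOc3ccccc3)cc2o1`, 0.4 ug/mL
compound 2, `CC(=O)c1ccc(OCCCCCOc2ccc3c(=O)cc(C(=O)O)oc3c2)cc1O`, 6.8 ug/mL
compound 3, `O=C(O)c1cc(=O)c2ccc(OCC(O)COc3ccccc3)cc2o1`, 7 ug/mL

All three were tested in a functional assay on ileum (Cavia porcellus) for antagonist activity, with a stated time of 30 s; on this read-out lower numbers stand for stronger inhibition and higher numbers for weaker inhibition. Compound 2 carries the change 4-acetyl-3-hydroxyphenyl in place of phenyl on an oxygen on a saturated carbon relative to compound 1, and this gave a 17-fold higher number from compound 1 to compound 2 (1.23 log units; beyond the scatter). Compound 4, `CC(=O)c1ccc(OCC(O)COc2ccc3c(=O)cc(C(=O)O)oc3c2)cc1O`, is not yet measured; it stands to compound 3 as compound 2 stands to compound 1, with 4-acetyl-3-hydroxyphenyl in place of phenyl on an oxygen on a saturated carbon, the same change at the same kind of place. The difference between the cores of compound 1 and compound 3 is not broken down here; their values show compound 3 at the higher number. Because the step of a 17-fold higher number from compound 1 to compound 2 (1.23 log units; beyond the scatter) was large, a step of similar direction is expected for compound 4, estimated as a 7.1-fold higher number from compound 3 to compound 4 (0.85 log units; beyond the scatter), though a different core may not repeat it exactly. Compound 4 is therefore expected to give about 50 ug/mL, within 12 ug/mL to 200 ug/mL.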

Compound 4, half-maximal inhibitory concentration: 28 ug/mL
Compound 4: the middle estimate sits 1.8-fold (0.25 log units) above what was measured, and the stated range covers the measured number.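

In this assay, 4-acetyl-3-hydroxyphenyl in place of phenyl again gave a weaker result, a 4.0-fold higher number from compound 3 to compound 4 (0.60 log units; beyond the scatter), so the direction of the change carried over to the second core. The size of the change did not carry over, and the two steps differ by more than the usual scatter: the same change on two cores in this assay, a 17-fold higher number (1.23 log units; beyond the scatter) from compound 1 to compound 2 and a 4.0-fold higher number (0.60 log units; beyond the scatter) from compound 3 to compound 4, 4.3-fold (0.63 log units) apart, beyond the scatter of two such steps. These two cores show only that the direction held in this pair of cases; they do not show why the size differed or what the change would do on any other core.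

On these data alone, it remains open whether the acetyl or the hydroxyl part of the new end accounts for the higher numbers. As far as these compounds go, how a phenyl end carrying an amine would read is also open.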